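The source may hold more compounds than are shown below. What is called first, only, known or untested is meant among the compounds shown, and "the series" means these compounds.

In a functional assay on MDA-MB-231 cells (Homo sapiens) for cytotoxicity, read by ELISA, with a stated time of 2 days (on this read-out lower numbers stand for stronger inhibition and higher numbers for weaker inhibition), compound 1 `Oc1ccc(-c2cc(-c3ccccc3)cc(-c3ccsc3)n2)cc1` gives 5700 nM and compound 2 `Oc1ccccc1-c1cc(-c2ccccc2)nc(-c2ccco2)c1` gives 4600 nM with the two lying within the scatter of each other. Compound 3 `Oc1cccc(-c2cc(-c3ccccc3)nc(-c3cccs3)c2)c1` at 17700 nM holds the highest of the three numbers and stands beyond the scatter from both of the others.

Within the data shown here, compound 4 `Oc1cccc(-c2cc(-c3ccccc3)nc(-c3ccco3)c2)c1` has no measurement yet and differs from compound 3 in one place: furan-2-yl in place of thiophen-2-yl on an aromatic carbon next to the ring nitrogen furan-2-yl in place of thiophen-2-yl on an aromatic carbon and nothing else changes.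

Among the measured compounds shown here, no measured pair isolates this exchange, so the size of the step in this assay has no direct precedent. For the measured compounds named here, compound 2 at 4600 nM is the only measured compound carrying furan-2-yl, but it differs from compound 3 elsewhere as well, so it suggests a direction and not a size. A lower number than that of compound 3 is therefore expected, of moderate size and possibly not clearing the scatter. The expected move a 2.0-fold lower number from compound 3 to compound 4 (0.29 log units; within the scatter) is an estimate resting on that single comparison. For compound 4 the estimated value is 9000 nM with an expected range from 3500 nM to 20000 nM on the same read-out.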

Compound 4, half-maximal inhibitory concentration: 20800 nM
For compound 4 the middle estimate is 2.3-fold (0.36 log units) below the measured one; measured number outside the range, above it.
By their numbers in this assay, from the lowest: compounds 2 and 1 (each within the scatter of the next); then compounds 3 and 4 (each within the scatter of the next).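

In this assay, the exchange of thiophen-2-yl for furan-2-yl on the aromatic carbon next to the ring nitrogen gives a 1.2-fold higher number from compound 3 to compound 4 (0.07 log units; within the scatter), so with a 3-hydroxyphenyl group present, the two five-membered aromatic rings cannot be told apart at this position. Among these compounds, the step of a 4.5-fold higher number from compound 2 to compound 4 (0.66 log units; beyond the scatter), with 3-hydroxyphenyl in place of 2-hydroxyphenyl and furan-2-yl held constant, is the first single-place comparison to clear the scatter, which shifts attention from the ring next to the ring nitrogen to where the hydroxyl sits on the phenyl group. Nothing in the data accounts for the size of either step.

The compounds shown leave open whether the exchange of thiophen-2-yl for furan-2-yl stays this small alongside a 2-hydroxyphenyl group, and whether the step between the two hydroxyphenyl groups keeps its size with thiophen-2-yl on the core. Also open, on these data alone, is how this position next to the ring nitrogen responds to a group of a different kind, such as an aliphatic amine or a carboxylic acid, in place of a five-membered aromatic ring.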